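The source may report more compounds than this note shows. Statements on the series, on what has been measured and on what is new or still open speak of the compounds shown alone.

Compounds measured so far:

Compound 1, `C[C@H]1CCC(=NNc2ccccc2)c2ncc(C(=O)O)c(=O)n21`, 0.3 umol/kg; 54.8 umol/kg (2 entries)
Compound 2, `CC1CC/C(=N\Nc2ccc(F)cc2)c2ncc(C(=O)O)c(=O)n21`, 12.2 umol/kg
Compound 3, `CC1CC/C(=N\Nc2cccc(Cl)c2)c2ncc(C(=O)O)c(=O)n21`, 0.6 umol/kg

In a functional assay on the whole organism for inhibition, with Rattus norvegicus as the target (on this read-out higher numbers stand for an effect only at larger amounts of compound and lower numbers for an effect already at smaller amounts), compound 3 gives 0.6 umol/kg, the lowest of the two single numbers. Compound 2 gives 12.2 umol/kg, and the two entries of compound 1, (the several entries of compound 1 in this assay, 0.3 umol/kg; 54.8 umol/kg (2 entries)), disagree too widely to place it. For the measured compounds named here, the only step with a single number on each side is a 20-fold lower number from compound 2 to compound 3 (1.31 log units; beyond the scatter), which carries the two compounds well beyond the usual scatter.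

Compound 4, `CC1CC/C(=N\Nc2ccc(Br)cc2)c2ncc(C(=O)O)c(=O)n21`, is not yet measured. It differs from compound 3 in one place: 4-bromophenyl in place of 3-chlorophenyl on an amine nitrogen. Going by the values given here, no measured pair shows exactly this exchange. The nearest guidance is the step from compound 2 to compound 3, where a 4-fluorophenyl was replaced by a 3-chlorophenyl on the amine nitrogen and the number fell strongly; compound 4 carries a halogen again in the 4-position of the phenyl, as compound 2 does, so part of that fall is expected to be given back.

Compound 4 is therefore expected to give about 3 umol/kg in this assay, within 0.6 umol/kg to 15 umol/kg, which means the estimated step of a 5.0-fold higher number from compound 3 to compound 4 (0.70 log units; beyond the scatter).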

Compound 4, dose for 50% inhibition: 0.8 umol/kg
Estimate against measurement, compound 4: 3.8-fold (0.57 log units) above; the range from low to high includes it.
By their numbers in this assay, from the lowest: compounds 3 and 4 (each within the scatter of the next); then compound 2.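

In this assay, the 4-bromophenyl group of compound 4 shows that the low numbers on this amine nitrogen do not depend on 3-chlorophenyl: a 1.3-fold higher number from compound 3 to compound 4 (0.12 log units; within the scatter). With bromo in place of fluoro on an aromatic carbon, the number changes strongly, giving a 15-fold lower number from compound 2 to compound 4 (1.18 log units; beyond the scatter). The earlier fall with 3-chlorophenyl therefore cannot be tied to that group's place on the phenyl alone, since the identity of the halogen also goes with a large step.

As far as these compounds go, compound 1 gives no usable reference without a halogen, as its entries disagree too widely: the several entries of compound 1 in this assay, 0.3 umol/kg; 54.8 umol/kg (2 entries) It remains open whether a methoxy group or a nitrile in place of the bromo would give a number close to that of compound 4 or close to that of compound 2.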